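Adding an acetyl group to a weak inhibitor

A few compounds are considered here, and "the series" means these few. Any claim that something is new, unique, unknown or untested is made for them only; others in the source may bear on it.

Compound 1 `CCc1oc([C@H](C)/C=C(\C)[C@H](OC(C)=O)[C@H](C)[C@@H](OC(=O)CC(C)C)[C@@H](C)c2oc([C@@H](C)[C@H](CC)OC(C)=O)c(C)c(=O)c2C)c(C)c(=O)c1C`: 24000 nM
Compound 2 `CCc1oc([C@H](C)/C=C(\C)[C@H](O)[C@H](C)[C@@H](OC(=O)CC(C)C)[C@@H](C)c2oc([C@@H](C)[C@@H](O)CC)c(C)c(=O)c2C)c(C)c(=O)c1C`: > 100000 nM (a limit)

In a functional assay on Hs 683 cells (Homo sapiens) for inhibition, read by MTT assay, with a stated time of 72 h (a higher number here means a weaker inhibitor, a lower number a stronger inhibitor), compound 2 gives > 100000 nM, which is a limit of the assay and not a number. Compound 3 `CCc1oc([C@H](C)/C=C(\C)[C@H](OC(C)=O)[C@H](C)[C@@H](OC(=O)CC(C)C)[C@@H](C)c2oc([C@@H](C)[C@@H](O)CC)c(C)c(=O)c2C)c(C)c(=O)c1C` differs from compound 2 by one change, hydroxy to acetoxy: acetyl in place of hydrogen on an oxygen on a saturated carbon. Going by the values given here, no measured step shows the size of this change. Compound 1 gives a real number, 24000 nM, so a modest move towards stronger inhibition in this assay is expected for compound 3. The expected change is an at least 2.0-fold lower number from compound 2 to compound 3 (0.30 log units; that floor lies within the scatter). Compound 3 is estimated at 50000 nM, with an expected range of 20000 nM to 100000 nM.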

Compound 3, half-maximal inhibitory concentration: 30000 nM
The estimate for compound 3 lay 1.7-fold (0.22 log units) above the measured number; low and high end bracket the measured number.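

In this assay, acetoxy in place of hydroxy on this oxygen gives an at least 3.3-fold lower number from compound 2 to compound 3 (0.52 log units; beyond the scatter), so a single acetyl is enough to bring a real number. Going by these compounds alone, the second acetyl, the one that compound 1 carries and compound 3 lacks, shows only a 1.3-fold higher number from compound 1 to compound 3 (0.10 log units; within the scatter), so those two compounds cannot be told apart. The full size of the first step stays unknown, since it starts from a limit: the limit of > 100000 nM in this assay, at which 1 of the 3 values shown sits.

Open, going by these compounds, is whether a longer ester such as butanoyl, or a methyl ether, would serve on this oxygen as acetyl does. Also open, on these data alone, is whether an amine there would keep any of the gain.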